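Swapping the Amide for a Nitrophenoxy Group

The compounds below may be only part of what the source reports. "The series", "measured", "known", "first", "only" and "open" are said of these compounds alone.

compound 2 `CC(C)=CCC/C(C)=C/CC1Cc2c(OCCCNC(=O)c3cccs3)cc(=O)n(CCCO)c2CC1(C)C`: 72.8%
compound 1 `CC(C)=CCC/C(C)=C/CC1Cc2c(OCCCNS(=O)(=O)c3ccc(Br)cc3)cc(=O)n(CCCO)c2CC1(C)C`: 15.2%

In a functional assay on PANC-1 cells (Homo sapiens) for inhibition, read by MTT assay, with a stated time of 24 h, tested at 10 uM (a higher number here means more inhibition at the concentration tested (going by the name of the read-out), a lower number less inhibition), compound 2 gives 72.8%, the higher of the two numbers shown; compound 1 gives 15.2%. Compound 3 `CC(C)=CCC/C(C)=C/CC1Cc2c(OCCCOc3ccc([N+](=O)[O-])cc3)cc(=O)n(CCCO)c2CC1(C)C` differs from compound 2 in one place: 4-nitrophenoxy in place of ((thiophen-2-yl)carbonyl)amino on a saturated chain carbon, three bonds along the chain from an oxygen on an aromatic ring. For the measured compounds named here, no measured step makes this exact change. Going by the values given here, the only step available, a number 57.6 percentage points higher from compound 1 to compound 2 (beyond the scatter), shows that the group at this position moves the read-out strongly, so another swap there may again shift it well beyond the scatter, most likely downward. The expected step is a number 32.8 percentage points lower from compound 2 to compound 3 (beyond the scatter). Compound 3 is therefore estimated at 40%, within a range from 10% to 75%.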

Compound 3, a percentage reported as inhibition, at one concentration (the size of the read-out at that concentration, not a potency): 65.1%
Compound 3: middle estimate off by 25.1 percentage points, on the low side; measured number inside the range.
By their numbers in this assay, from the lowest: compound 1; then compounds 3 and 2 (each within the scatter of the next).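

In this assay, the swap to 4-nitrophenoxy gives a number 7.7 percentage points lower from compound 2 to compound 3 (within the scatter), so this position takes a different ring and a group with 0 hydrogen-bond donors without moving the read-out beyond the scatter. For the compounds shown here, the ((thiophen-2-yl)carbonyl)amino group is therefore not the only group here that goes with a high number. The ((4-bromophenyl)sulfonyl)amino group stands apart among the three, with a number 49.9 percentage points higher from compound 1 to compound 3 (beyond the scatter).

Nothing available explains why these groups read as they do. Going by these compounds, whether a simple amine or a carboxylic acid at this position, or a longer chain carrying the 4-nitrophenoxy group, would keep the number high remains open.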